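Restoring an alkyl amine: cyclopropylmethyl replaces cyclopropylcarbonyl

The compounds below may be only part of what the source reports. "The series", "measured", "known", "first", "only" and "open" are said of these compounds alone.

Within the data shown here, compound 2 `O=C(C1CC1)N1CCC(NCCSC(c2ccc(F)cc2)c2ccc(F)cc2)CC1` holds the higher of the two numbers so far in an assay on membranes from Cortex for displacement of a labelled ligand from Sigma non-opioid intracellular receptor 1 (Cavia porcellus), read by scintillation counting, with a stated time of 120 min; on this read-out higher numbers stand for weaker inhibition and lower numbers for stronger inhibition: compound 2 gives 46.4 nM, whereas compound 1 `Fc1ccc(C(SCCNC2CCN(Cc3ccccc3)CC2)c2ccc(F)cc2)cc1` gives 3.81 nM. Among the measured compounds shown here, the only measured step, a 12-fold higher number from compound 1 to compound 2 (1.09 log units; beyond the scatter), is large and shows that the group on the ring nitrogen matters. Compound 3 `Fc1ccc(C(SCCNC2CCN(CC3CC3)CC2)c2ccc(F)cc2)cc1` has not been measured; it differs from compound 2 by cyclopropylmethyl in place of cyclopropylcarbonyl on an amine nitrogen in a ring. The step at the same ring nitrogen, a 12-fold higher number from compound 1 to compound 2 (1.09 log units; beyond the scatter), is the one that bears on this change, and it points the other way here, since compound 3 removes the carbonyl that entered with compound 2 while keeping a group smaller than the benzyl of compound 1. The author therefore expects a fall in the number, estimated as a 5.8-fold lower number from compound 2 to compound 3 (0.76 log units; beyond the scatter), beyond the scatter but probably short of a full return to the value of compound 1. Compound 3 is expected to give about 8 nM in this assay, with a range from 2.5 nM to 25 nM.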

Compound 3, inhibition constant: 269 nM
Estimate against measurement, compound 3: 34-fold (1.53 log units) below; measured number above the stated range.
By their numbers in this assay, from the lowest: compound 1; then compound 2; then compound 3.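

In this assay, taking out the carbonyl did not move the number back toward that of compound 1: the change gave a 5.8-fold higher number from compound 2 to compound 3 (0.76 log units; beyond the scatter) and so ran against the direction of the earlier step, which means that the carbonyl alone cannot account for the loss seen with compound 2. The step of a 71-fold higher number from compound 1 to compound 3 (1.85 log units; beyond the scatter) isolates a single change, cyclopropyl in place of phenyl on a saturated chain carbon bound to an amine nitrogen in a ring, and it shows that this ring terminus matters at this position, something the earlier pair could not show since it changed both the carbonyl and the ring together. No measurement offered here explains either rise.

The compounds shown leave open whether a cyclohexylmethyl group would keep the low number of compound 1, which would separate the phenyl ring itself from the size of the group. They also leave open how a benzoyl group, which joins the carbonyl to a phenyl ring, or a longer chain such as phenethyl would behave on the same ring nitrogen.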